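The compounds below may be only part of what the source reports. "The series", "measured", "known", "first", "only" and "open" are said of these compounds alone.

Compound 1, `CC(=O)Oc1ccccc1C(=O)O[C@H]1CO[C@H]2[C@@H]1OC[C@H]2OC(C)=O`: in an ADME assay on a cell-free system (plasma, Homo sapiens) for metabolic stability, with Plasma (Rattus norvegicus) as the target, read by HPLC, at pH 7.4 (a lower number here means that the compound disappears faster, a higher number that the compound lasts longer), compound 1 gives 0.0608 h.
Compound 2, `CC(=O)Oc1ccccc1C(=O)O[C@H]1CO[C@H]2[C@@H]1OC[C@H]2OC(=O)c1ccccc1C`: in this assay compound 2 gives 0.035 h.
Compound 3, `CC(=O)Oc1ccccc1C(=O)O[C@H]1CO[C@H]2[C@@H]1OC[C@H]2OC(=O)c1cccnc1`: in this assay compound 3 gives 0.0232 h.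

All three share the same core and differ only in the group attached to one carbonyl carbon. Compound 2 stands second highest of the three numbers in this assay; its nearest neighbour is compound 3 and its furthest is compound 1, and both gaps lie within the scatter, so no order among the three is claimed.

The unmeasured compound 4, `CC(=O)Oc1ccccc1C(=O)O[C@H]1CO[C@H]2[C@@H]1OC[C@H]2OC(=O)c1cnoc1C`, differs from compound 2 in one place: 5-methyl-1,2-oxazol-4-yl in place of 2-methylphenyl on a carbonyl carbon.

Within the data shown here, two measured steps bear on this change. Going from methyl to a ring on that carbonyl carbon gave a 1.7-fold lower number from compound 1 to compound 2 (0.24 log units; within the scatter) and a 2.6-fold lower number from compound 1 to compound 3 (0.42 log units; beyond the scatter); between the two rings themselves the record shows a 1.5-fold lower number from compound 2 to compound 3 (0.18 log units; within the scatter). A five-membered aromatic ring with 2 hetero atoms is new in this set, so the expectation rests on thin ground. The step from compound 2 to compound 4 is expected to be small, a 1.3-fold lower number from compound 2 to compound 4 (0.10 log units; within the scatter), and likely within the scatter.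

For compound 4 the estimated value in this assay is 0.028 h, with a range from 0.014 h to 0.056 h.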

Compound 4, half-life: 0.193 h
For compound 4 the middle estimate is 6.9-fold (0.84 log units) below the measured one, and the stated range ends below it.
By their numbers in this assay, from the lowest: compounds 3, 2 and 1 (each within the scatter of the next, the first and the last beyond it); then compound 4.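

The position proved able to move the number upward as well as downward: with 5-methyl-1,2-oxazol-4-yl on the carbonyl carbon, this assay shows a 5.5-fold higher number from compound 2 to compound 4 (0.74 log units; beyond the scatter) and an 8.3-fold higher number from compound 3 to compound 4 (0.92 log units; beyond the scatter), whereas no earlier ring had given a higher number than methyl. A ring in place of methyl therefore does not by itself go with a shorter half-life, as pyridin-3-yl gave a 2.6-fold lower number from compound 1 to compound 3 (0.42 log units; beyond the scatter) but 5-methyl-1,2-oxazol-4-yl, which goes against that earlier direction, gave a 3.2-fold higher number from compound 1 to compound 4 (0.50 log units; beyond the scatter). No measurement in hand accounts for the size or direction of this change.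

Among these compounds, with only one five-membered ring in the set, it remains open whether the longer half-life follows that ring, its nitrogen and oxygen, or the methyl on it; an unsubstituted 1,2-oxazol-4-yl, a thiophene ring or a plain phenyl on the same carbonyl carbon would begin to separate these. The half-life also leaves open which part of each compound is lost first, and whether a saturated ring or a longer chain at this position would give a similar number.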